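A few compounds are considered here, and "the series" means these few. Any claim that something is new, unique, unknown or untested is made for them only; others in the source may bear on it.

Measured in a functional assay on MCF7 cells (Homo sapiens) for inhibition, read by MTT assay, with a stated time of 72 h; a higher number here means a weaker inhibitor, a lower number a stronger inhibitor:
Compound 1 `CC(C)[C@H](NC(=O)c1cc(Cl)ccc1OCCN)C(=O)Nc1ccc([N+](=O)[O-])cc1Cl`: > 10000 nM (a limit)
Compound 2 `CC(C)C[C@H](NC(=O)c1cc(Cl)ccc1OCCN)C(=O)Nc1ccc([N+](=O)[O-])cc1Cl`: > 10000 nM (a limit)

In this assay, compound 2 stands at > 10000 nM, which is a limit of the assay and not a number. It shares this position with compound 1: the limit of > 10000 nM in this assay, at which 2 of the 2 values shown sit. Compound 3 `CC(C)(C)OC(=O)CC[C@H](NC(=O)c1cc(Cl)ccc1OCCN)C(=O)Nc1ccc([N+](=O)[O-])cc1Cl` differs from compound 2 as follows: (tert-butoxycarbonyl)methyl in place of isopropyl on a saturated chain carbon, two bonds along the chain from an amide-type nitrogen and a carbonyl carbon. For the measured compounds named here, the only measured step that bears on this change is a step that the two limits leave unreadable from compound 1 to compound 2, and it gives no size to build on. No step beyond the scatter is therefore expected in this assay. The expected step is a step that the limit leaves unreadable from compound 2 to compound 3. For compound 3 the estimated value is 15000 nM, with an expected range of 5000 nM to 40000 nM.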

Compound 3, half-maximal inhibitory concentration: 3080 nM
For compound 3 the middle estimate is 4.9-fold (0.69 log units) above the measured one, and the stated range ends above it.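

In this assay, for the compounds shown here, the change to 2-(tert-butoxycarbonyl)ethyl is the first at this position that can be read, with an at least 3.2-fold lower number from compound 2 to compound 3 (0.51 log units; beyond the scatter) and an at least 3.2-fold lower number from compound 1 to compound 3 (0.51 log units; beyond the scatter). Going by these compounds alone, the step between isopropyl and isobutyl cannot be read, so only this change shows that the position can move the value. Compound 3 alone carries a number rather than a limit: the limit of > 10000 nM in this assay, at which 2 of the 3 values shown sit. Going by these compounds, how a free carboxylic acid, an amine or a longer chain at this position would read in this assay stays open, as does whether the value depends on the tert-butyl ester itself.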